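A few compounds are considered here, and "the series" means these few. Any claim that something is new, unique, unknown or untested is made for them only; others in the source may bear on it.

Compound 1, `c1cc2c(s1)CCOC21CCN(Cc2ccc3c(c2)CCCO3)CC1`, gives > 30 mL/min/g in an ADME assay on microsomes from liver (Mus musculus) for metabolic stability, read by LC-MS, using NADPH, with a stated time of 30 min, tested at 0.5 uM; a lower number here means slower removal, a higher number faster removal of the compound.
Compound 2, `Cc1ccc(CN2CCC3(CC2)OCCc2sccc23)cc1`, gives > 30 mL/min/g.
Compound 3, `CC(C)(C)c1ccc(CN2CCC3(CC2)OCCc2sccc23)cc1`, gives > 30 mL/min/g.

Each of these three values is a limit of this assay, not a number: the compounds were cleared faster than the assay can follow, and all three sit at the same point, (the limit of > 30 mL/min/g in this assay, at which 3 of the 3 values shown sit). Compound 3 therefore stands only at a limit, and nothing sets it apart from the other two.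

Compound 4, `FS(F)(F)(F)(F)c1ccc(CN2CCC3(CC2)OCCc2sccc23)cc1`, differs from compound 3 in one place: a group of 6 heavy atoms (5 fluorine, 1 sulfur; no ring) in place of a group of 4 heavy atoms (4 carbon; no ring), on an aromatic carbon.

Going by the values given here, only one measured step touches this position, the step that the two limits leave unreadable from compound 2 to compound 3, and its size cannot be read, since both ends are limits. No readable step is available, so no direction or size of change in this assay can be drawn from the data, and compound 4 is expected to sit at the same limit as the others.

Compound 4 is therefore expected to give about 45 mL/min/g, with a likely range from 20 mL/min/g to 120 mL/min/g. The step that the limit leaves unreadable from compound 3 to compound 4 is expected to be unreadable rather than a measurable change.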

Compound 4, intrinsic clearance in a liver preparation (reported as CLH), per the amount of preparation that the assay uses: 18.2 mL/min/g
The estimate for compound 4 lay 2.5-fold (0.39 log units) above the measured number; the measured number lies below the stated range.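

At this position, on an aromatic carbon para to a large group, compound 4 is the only compound shown that gives a number rather than a limit in this assay. The other three compounds each give only a limit: the limit of > 30 mL/min/g in this assay, at which 3 of the 4 values shown sit. As far as these compounds go, the group of 6 heavy atoms (5 fluorine, 1 sulfur; no ring) gives an at least 1.6-fold lower number from compound 3 to compound 4 (0.21 log units; that floor lies within the scatter) in place of tert-butyl, and in place of one carbon atom it gives an at least 1.6-fold lower number from compound 2 to compound 4 (0.21 log units; that floor lies within the scatter); both are floors, so the true size of each step remains unknown.

The step between the two compounds at the limit, compound 2 and compound 3, cannot be read. From the compounds shown here alone, it remains open whether a trifluoromethyl group, a nitrile or an amine at this same place would also give a number rather than a limit.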